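Dichlorophenyl in Place of Difluorophenyl on the Carbonyl

The source may hold more compounds than are shown below. What is called first, only, known or untested is meant among the compounds shown, and "the series" means these compounds.

Among the compounds with values here, compound 3 `CN(C(=O)NC(=O)c1ccc(F)c(F)c1)c1nc(C(F)(F)F)c(C(=O)N/N=C/c2ccccc2C(F)(F)F)s1` gives the lowest of the three numbers so far in a functional assay on HepG2 cells (Homo sapiens) for inhibition, read by MTT assay, with a stated time of 72 h (on this read-out higher numbers stand for weaker inhibition and lower numbers for stronger inhibition), at 10.4 ug/mL, though every gap to the others lies within the scatter. Its nearest neighbour is compound 1 `CN(C(=O)NC(=O)c1ccc(Cl)cc1Cl)c1nc(C(F)(F)F)c(C(=O)N/N=C/c2cccc(C(F)(F)F)c2)s1`, which in this assay gives 11.2 ug/mL; compound 2 `CN(C(=O)NC(=O)c1ccc(Cl)cc1Cl)c1nc(C(F)(F)F)c(C(=O)N/N=C/c2ccc(C(F)(F)F)cc2)s1` gives 12.4 ug/mL. Within the data shown here, the one step between measured compounds, a 1.1-fold higher number from compound 1 to compound 2 (0.04 log units; within the scatter), concerns the trifluoromethylphenyl on the carbon with a double bond to nitrogen and is also within the scatter.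

Compound 4 `CN(C(=O)NC(=O)c1ccc(Cl)cc1Cl)c1nc(C(F)(F)F)c(C(=O)N/N=C/c2ccccc2C(F)(F)F)s1` differs from compound 3 in a single place: 2,4-dichlorophenyl in place of 3,4-difluorophenyl on a carbonyl carbon. Among the measured compounds shown here, no measured pair shows this exchange directly. What the data do show is that compounds 1 and 2, which carry the same 2,4-dichlorophenyl as compound 4, give numbers close to that of compound 3, and that the exchange of trifluoromethylphenyl in a 1.1-fold higher number from compound 1 to compound 2 (0.04 log units; within the scatter) changed little. The step to compound 4 is therefore expected to be small, as a 1.1-fold higher number from compound 3 to compound 4 (0.04 log units; within the scatter), with no direction beyond the scatter. Compound 4 is expected to give 11.5 ug/mL in this assay, within a range from 6 ug/mL to 22 ug/mL.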

Compound 4, half-maximal inhibitory concentration: 10.7 ug/mL
The estimate for compound 4 lay 1.1-fold (0.03 log units) above the measured number, within the range that was stated.
By their numbers in this assay, from the lowest: compounds 3, 4, 1 and 2 (each within the scatter of the next).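

In this assay, the exchange on the carbonyl carbon can now be read within a single pair: 2,4-dichlorophenyl in place of 3,4-difluorophenyl gives a 1.0-fold higher number from compound 3 to compound 4 (0.01 log units; within the scatter) and so does not separate the two groups when 2-(trifluoromethyl)phenyl stands on the carbon with a double bond to nitrogen. Compound 4 also completes the set of three trifluoromethylphenyl groups on that carbon with 2,4-dichlorophenyl held constant: a 1.2-fold lower number from compound 2 to compound 4 (0.06 log units; within the scatter) and a 1.0-fold lower number from compound 1 to compound 4 (0.02 log units; within the scatter) join a 1.1-fold higher number from compound 1 to compound 2 (0.04 log units; within the scatter) in showing no difference beyond the scatter among the 2-, 3- and 4-(trifluoromethyl)phenyl groups. No measurement is available that could explain this flat picture at either place.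

The compounds shown leave open whether the numbers would stay this close with a group of a different kind on the carbonyl carbon, such as an unsubstituted phenyl or a phenyl carrying an amine or a carboxylic acid. They also leave open what happens on the carbon with a double bond to nitrogen when the trifluoromethyl gives way to a methoxy group or a hydroxyl group.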